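This account rests on a few compounds, and the source may have more. Where it says the series, first, only, none or still open, it means among the compounds named here.

Measured in a physicochemical assay for solubility, at pH 7.4; a lower number here means a less soluble compound, a higher number a more soluble compound:
compound 1, `Cc1cc(C)n(-c2nc(C(F)(F)F)cc(=O)[nH]2)n1`: 200000 nM
compound 2, `Cc1cc(C2CC2)n(-c2nc(C(F)(F)F)cc(=O)[nH]2)n1`: 160000 nM
compound 3, `Cc1cc(N)n(-c2nc(C(F)(F)F)cc(=O)[nH]2)n1`: 200000 nM

All three share one core and differ only in a single group on the five-membered ring. Compound 2 differs from compound 1 by cyclopropyl in place of methyl on an aromatic carbon, and in this assay that change gave a 1.3-fold lower number from compound 1 to compound 2 (0.10 log units; within the scatter). Compound 3 differs from compound 1 by amino in place of methyl on an aromatic carbon, with no change at the digits printed from compound 1 to compound 3 (within the scatter). Between the two remaining compounds, a 1.3-fold higher number from compound 2 to compound 3 (0.10 log units; within the scatter). Compound 3 thus stands level with compound 1 at the digits given, and none of the three is separated from the others by more than the scatter.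

Compound 4, `Nc1cc(C2CC2)nn1-c1nc(C(F)(F)F)cc(=O)[nH]1`, has not yet been measured in this assay. It differs from compound 3 by cyclopropyl in place of methyl on an aromatic carbon. For the measured compounds named here, this is the same kind of change as the one from compound 1 to compound 2, but the surroundings are not the same word for word: in compound 1 the changed carbon is next to the ring atom that bears a large group and two ring bonds from the ring atom that bears a methyl group, whereas in compound 3 it is two ring bonds from the ring atom that bears a large group and two ring bonds from the ring atom that bears an amino group.

The step from compound 3 to compound 4 is expected to be about a 1.3-fold lower number from compound 3 to compound 4 (0.12 log units; within the scatter). Going by the values given here, this rests on the single earlier instance of the change, a 1.3-fold lower number from compound 1 to compound 2 (0.10 log units; within the scatter), which stayed within the scatter. Compound 4 is therefore estimated at 150000 nM, with a range from 80000 nM to 300000 nM.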

Compound 4, solubility: 10000 nM
Compound 4: middle estimate off by 15-fold (1.18 log units), on the high side; the whole stated range lies above it.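

In this assay, cyclopropyl in place of methyl gave a 1.3-fold lower number from compound 1 to compound 2 (0.10 log units; within the scatter) on the core of compound 1, whereas the same exchange on the core of compound 3, at an aromatic carbon two ring bonds from the ring atom that bears an amino group, gave a 20-fold lower number from compound 3 to compound 4 (1.30 log units; beyond the scatter). This shows that the size of this change did not carry from one core to the other in this series: a step within the scatter on one core became a large step, beyond the scatter, on the other. It does not show which difference between the two cores matters or how the change would behave on a third core, as these are only two instances, and nothing at hand accounts for the gap between them.

The compounds shown leave open whether the large step belongs to cyclopropyl itself or would also appear with an ethyl or isopropyl group at the same carbon. They also leave open whether, with cyclopropyl in place, a dimethylamino group, a hydroxyl or a carboxylic acid in place of the amino group would give a number closer to that of compound 3.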